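The source may report more compounds than this note shows. Statements on the series, on what has been measured and on what is new or still open speak of the compounds shown alone.

Measured so far:
compound 1, `Cc1ccc(C(=O)CSc2nnc(C)n2N2C(=O)c3ccccc3C2=O)cc1`, > 200000 nM
compound 2, `CCc1nnc(SCc2ccccc2)n1N1C(=O)c2ccccc2C1=O`, > 200000 nM

In a functional assay on HepG2 cells (Homo sapiens) for cytotoxicity, read by MTT assay, with a stated time of 48 h (on this read-out higher numbers stand for weaker inhibition and lower numbers for stronger inhibition), compound 2 gives > 200000 nM, and this is a limit of the assay rather than a number. Compound 1 likewise gives > 200000 nM in this assay, again only a limit. Compound 2 therefore stands exactly where the other shown value stands, namely at the limit of > 200000 nM in this assay, at which 2 of the 2 values shown sit; neither value places it above or below anything else.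

Compound 3, `CCc1nnc(SCC(=O)c2ccc(C)cc2)n1N1C(=O)c2ccccc2C1=O`, has not been measured in this assay. It differs from compound 2 in one place: (4-methylphenyl)carbonyl in place of phenyl on a saturated chain carbon bound to a sulfur. No step between two measured compounds is available to calibrate this change, so the direction and size of its effect are not known from the shown data. Since both compound 1 and compound 2 sit at the limit, the expected step from compound 2 to compound 3, a step that the limit leaves unreadable from compound 2 to compound 3, is one that stays within the scatter, with no change beyond it, and most likely a further limit. Compound 3 is estimated at 300000 nM, with a range from 150000 nM to 1000000 nM.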

Compound 3, half-maximal inhibitory concentration: > 200000 nM
Compound 3 ended at the assay's limit; the forecaster's own chance of this, stated with the estimate: 85%; the middle value lies beyond the limit too.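

Compound 3 sits at the same limit as compound 1 and compound 2, so no step among these compounds in this assay can be read: the limit of > 200000 nM in this assay, at which 3 of the 3 values shown sit. The compounds shown leave open how strongly any of them acts in this assay and whether (4-methylphenyl)carbonyl in place of phenyl changes the read-out at all.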